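The source may report more compounds than this note shows. Statements on the series, on what has been measured and on what is new or still open speak of the compounds shown alone.

Measured so far:
Compound 1 `CCOc1cc(/C=C/C(=O)c2ccncc2)cc(OCC)c1OCC`: in an assay on cells for inhibition of cytochrome P450 1A1 (Homo sapiens), read by MTT assay (a lower number here means that less compound is needed, a higher number that more compound is needed for the effect), compound 1 gives 14000 nM.
Compound 2 `CCOc1cc(/C=C/C(=O)c2ccncc2)cc(OC)c1OCC`: in this assay compound 2 gives 14000 nM.

Compound 2 stands level with compound 1 at the digits reported; the step from compound 1 to compound 2 was no change at the digits printed from compound 1 to compound 2 (within the scatter), within the usual scatter. Compound 3 `CCOc1cc(/C=C/C(=O)c2ccncc2)cc(OC)c1OC` differs from compound 2 by hydrogen in place of methyl on a saturated chain carbon bound to an oxygen on an aromatic ring, or read one bond further out, ethoxy to methoxy. Within the data shown here, only one measured step bears on this: the same kind of change, ethoxy to methoxy on the shared core, from compound 1 to compound 2, which gave no change at the digits printed from compound 1 to compound 2 (within the scatter). A step of the same kind is therefore expected to give no change beyond the scatter in this assay, so compound 3 is estimated at 14000 nM, with a range from 7000 nM to 30000 nM. The expected step from compound 2 to compound 3 is no change at the digits printed from compound 2 to compound 3 (within the scatter).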

Compound 3, half-maximal effective concentration: 14000 nM
Compound 3: the middle estimate sits on the measured number at the digits printed, within the range that was stated.
By their numbers in this assay, from the lowest: compounds 1, 2 and 3 (each within the scatter of the next).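

In this assay, replacing a second ethoxy group with methoxy on the shared core gives no change at the digits printed from compound 2 to compound 3 (within the scatter), the same reading as the first such replacement, no change at the digits printed from compound 1 to compound 2 (within the scatter). This change has now been seen at two different oxygens on the aromatic ring, and neither time did the number move beyond the scatter, so the flat result no longer rests on a single step. No available data explain why these steps read as flat.

These compounds only trade ethyl for methyl, so they leave open whether a longer chain such as propoxy, or an amine or a carboxylic acid in place of these groups, would shift the number. They also leave open whether replacing the remaining ethoxy group with methoxy would read the same way.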